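This account rests on a few compounds, and the source may have more. Where it says the series, first, only, none or still open, it means among the compounds named here.

The compounds were tested in an assay on isolated protein for inhibition of ribosomal protein S6 kinase alpha-2 (Homo sapiens), read by fluorescence, with a stated time of 20 min; on this read-out lower numbers stand for stronger inhibition and higher numbers for weaker inhibition. Compound 1 `COc1ccc(NCN2C(=O)c3cccc(N)c3C2=O)cc1` gives 3530 nM in this assay. Compound 2 `COc1ccc(NCN2C(=O)c3ccc(N)cc3C2=O)cc1` is built from the same atoms as compound 1, joined differently; the difference between the two cores is not broken down here. In this assay compound 2 gives 590 nM, a number that sits within the usual scatter of compound 3. Compound 3 `COc1ccc(NCN2C(=O)c3cccc(NC(=O)c4ccccc4)c3C2=O)cc1` is compound 1 with one change, (benzoyl in place of hydrogen on a nitrogen on an aromatic ring). In this assay compound 3 gives 990 nM, which is a 3.6-fold lower number from compound 1 to compound 3 (0.55 log units; beyond the scatter). Compound 4 `COc1ccc(NCN2C(=O)c3ccc(NC(=O)c4ccccc4)cc3C2=O)cc1` is compound 2 carrying the same change, (benzoyl in place of hydrogen on a nitrogen on an aromatic ring), at the same kind of place, and it has not yet been measured in this assay. Among the compounds with values here, the one earlier example of this change gave a 3.6-fold lower number from compound 1 to compound 3 (0.55 log units; beyond the scatter). Resting on that earlier step alone, a change of a 2.5-fold lower number from compound 2 to compound 4 (0.39 log units; beyond the scatter) is expected here, taken somewhat smaller since a single example carries little weight. Compound 4 is therefore estimated at 240 nM in this assay, most likely between 80 nM and 700 nM.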

Compound 4, half-maximal inhibitory concentration: 2160 nM
Estimate against measurement, compound 4: 9.0-fold (0.95 log units) below; the whole stated range lies below it.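

Benzoyl in place of hydrogen on the aromatic nitrogen did not carry over from one core to the other: on the core of compound 2 it weakened inhibition, with a 3.7-fold higher number from compound 2 to compound 4 (0.56 log units; beyond the scatter), whereas it had strengthened inhibition on the core of compound 1. So in this series the effect of the change depends on which core carries it, and a step read on one of these cores is a poor guide to the other, as the two steps set side by side show: the same change on two cores in this assay, a 3.6-fold lower number (0.55 log units; beyond the scatter) from compound 1 to compound 3 and a 3.7-fold higher number (0.56 log units; beyond the scatter) from compound 2 to compound 4, 13-fold (1.12 log units) apart, beyond the scatter of two such steps. This rests on a single pair of compounds for each core, so it does not show why the cores part ways, nor whether the same split would appear with any other group.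

The compounds shown leave open whether an acetyl or a longer chain on the same nitrogen would split between the two cores as benzoyl does. They also leave open whether the split would survive if a carboxylic acid were added to the benzoyl ring.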